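A few compounds are considered here, and "the series" means these few. Any claim that something is new, unique, unknown or untested is made for them only; others in the source may bear on it.

In a functional assay on MCF7 cells (Homo sapiens) for inhibition, read by MTT assay, with a stated time of 48 h (a higher number here means a weaker inhibitor, a lower number a stronger inhibitor), compound 2 `COc1ccc(C(c2c[nH]c3ccc(Br)cc23)c2c[nH]c3ccc(Br)cc23)cc1OC` gives 7800 nM and compound 1 `Brc1ccc2[nH]cc(C(c3ccccc3)c3c[nH]c4ccc(Br)cc34)c2c1` gives 5500 nM, so these two numbers lie within the scatter of each other. Compound 3 `COc1ccc(OC)c(C(c2c[nH]c3ccc(Br)cc23)c2c[nH]c3ccc(Br)cc23)c1` carries 2,5-dimethoxyphenyl in place of 3,4-dimethoxyphenyl on a saturated chain carbon bound to two aromatic carbons. For the measured compounds named here, the only measured step, a 1.4-fold higher number from compound 1 to compound 2 (0.15 log units; within the scatter), stayed within the scatter, so no step beyond the scatter is expected in this assay, although no measured compound carries 2,5-dimethoxyphenyl. The expected step is a 1.1-fold lower number from compound 2 to compound 3 (0.05 log units; within the scatter). For compound 3 the estimate is 7000 nM, with an expected range of 3000 nM to 16000 nM.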

Compound 3, half-maximal inhibitory concentration: 2800 nM
Compound 3: middle estimate off by 2.5-fold (0.40 log units), on the high side; measured number outside the range, below it.
By their numbers in this assay, from the lowest: compounds 3, 1 and 2 (each within the scatter of the next, the first and the last beyond it).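

In this assay, compounds 2 and 3 hold the same atoms, so the arrangement of the methoxy groups on the phenyl ring alone separates them (a 2.8-fold lower number from compound 2 to compound 3 (0.44 log units; beyond the scatter)), a modest change. Compared with plain phenyl, 2,5-dimethoxyphenyl gives a smaller difference that stays within the scatter (a 2.0-fold lower number from compound 1 to compound 3 (0.29 log units; within the scatter)). Nothing available here explains why the arrangement matters.
On these data alone, whether a single methoxy group would give a similar number remains open. So does what an amine or a carboxylic acid on this ring would do.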